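Cyclohexyl to phenyl on an inactive amide

The source may hold more compounds than are shown below. What is called first, only, known or untested is meant among the compounds shown, and "the series" means these compounds.

Compound 1 `CC(C)(C)NC(=O)CCc1cccc2c1B(O)OC2`: > 100000 nM (a limit)
Compound 2 `O=C(CCc1cccc2c1B(O)OC2)NC1CCCCC1`: > 100000 nM (a limit)

In a functional assay on HCT-116 cells (Homo sapiens) for antiproliferative activity, read by MTT assay, with a stated time of 72 h (a lower number here means a stronger inhibitor, a higher number a weaker inhibitor), compound 2 gives > 100000 nM, which is a limit of the assay and not a number. Compound 3 `O=C(CCc1cccc2c1B(O)OC2)Nc1ccccc1` keeps the shared core and changes one group, with phenyl in place of cyclohexyl on an amide-type nitrogen. Within the data shown here, one measured step bears on this change, a step that the two limits leave unreadable from compound 1 to compound 2. It swaps a different group at the same nitrogen, and its size cannot be read. Both values are the same limit: the limit of > 100000 nM in this assay, at which 2 of the 2 values shown sit. Among the measured compounds shown here, no measured compound carries phenyl there. For the measured compounds named here, with a step that the two limits leave unreadable from compound 1 to compound 2 as the only guide, no clear gain is expected in this assay, and another limit is the likeliest result. The expected change is a number no higher from compound 2 to compound 3 (the limit leaves the size open). For compound 3 the estimate is 100000 nM, with an expected range of 30000 nM to 200000 nM.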

Compound 3, half-maximal inhibitory concentration: 350 nM
Compound 3: the middle estimate sits 290-fold (2.46 log units) above what was measured; the measured number lies below the stated range.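

In this assay, the group on the amide-type nitrogen decides whether any activity can be read at all: phenyl in place of cyclohexyl gives an at least 280-fold lower number from compound 2 to compound 3 (2.45 log units; beyond the scatter), and phenyl in place of tert-butyl gives an at least 280-fold lower number from compound 1 to compound 3 (2.45 log units; beyond the scatter). The earlier compounds could not reveal this sensitivity, since neither gave a number, only a limit of the assay: the limit of > 100000 nM in this assay, at which 2 of the 3 values shown sit.

Cyclohexyl and phenyl each bring 6 carbon atoms in one six-membered ring, and the listed difference between them is that the phenyl ring is aromatic and the cyclohexyl ring is not.

With only one aromatic group shown at this nitrogen, it remains open whether aromaticity itself is what matters. A pyridyl ring, a chlorophenyl group or a benzyl group at the same nitrogen would show how far this gain extends.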